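The compounds below may be only part of what the source reports. "The series", "measured", "known", "first", "only" and "open" are said of these compounds alone.

Measured compounds in an assay on CHO cells for agonist activity at Free fatty acid receptor 1 (Homo sapiens), read by luminescence, with a stated time of 20 s; a lower number here means that less compound is needed, a higher number that more compound is needed for the effect:
- compound 1 `O=C(O)CC(c1ccc(OCc2cccc(-c3ccc(C(F)(F)F)cc3)c2)cc1)c1cccnc1` — 400 nM
- compound 2 `O=C(O)CC(c1ccc(OCc2cccc(-c3ccc(C(F)(F)F)cc3)c2)cc1)c1nccs1` — 120 nM

Among the compounds with values here, compound 2 holds the lowest number of the two measured in this assay; its nearest neighbour is compound 1, and the one measured step, a 3.3-fold lower number from compound 1 to compound 2 (0.52 log units; beyond the scatter), lies beyond the scatter. Compound 3 `Cn1ccnc1C(CC(=O)O)c1ccc(OCc2cccc(-c3ccc(C(F)(F)F)cc3)c2)cc1` is not yet measured. Its difference from compound 2 is 1-methyl-1H-imidazol-2-yl in place of 1,3-thiazol-2-yl on a saturated chain carbon bound to an aromatic carbon and a saturated chain carbon. Within the data shown here, the only measured step that bears on this position is a 3.3-fold lower number from compound 1 to compound 2 (0.52 log units; beyond the scatter), a modest move that came from exchanging one aromatic ring for another at the same saturated chain carbon. Among the measured compounds shown here, the step from compound 2 to compound 3 again swaps one five-membered aromatic ring with 2 hetero atoms for another of the same size class, so no comparable precedent exists in this set for the direction. The expectation for compound 3 is therefore a step of a 1.7-fold higher number from compound 2 to compound 3 (0.22 log units; within the scatter), at the edge of the scatter and leaning toward a somewhat higher number, with wide uncertainty. Compound 3 is estimated at 200 nM, range 60 nM to 700 nM.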

Compound 3, half-maximal effective concentration: 130 nM
Beside the measured number, compound 3's estimate is 1.5-fold (0.19 log units) above it; the range from low to high includes it.
By their numbers in this assay, from the lowest: compounds 2 and 3 (each within the scatter of the next); then compound 1.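

In this assay, 1-methyl-1H-imidazol-2-yl in place of 1,3-thiazol-2-yl on the saturated chain carbon gives a 1.1-fold higher number from compound 2 to compound 3 (0.03 log units; within the scatter), so at this position the move from 5 to 6 heavy atoms, with sulfur exchanged for nitrogen, produces no change beyond the scatter. Against pyridin-3-yl, the new group gives a 3.1-fold lower number from compound 1 to compound 3 (0.49 log units; beyond the scatter), which means that the lower number is no longer tied to 1,3-thiazol-2-yl alone: both five-membered aromatic rings shown stand apart from pyridin-3-yl, and no compound here goes against that. No measurement at hand accounts for this reading of the position.

Still open, as far as these compounds go, is how a 1,3-oxazol-2-yl, a 1H-imidazol-2-yl without the methyl group, or a 1-ethyl-1H-imidazol-2-yl would read at this saturated chain carbon. Also open, from the compounds shown here alone, is whether a plain phenyl group would fall with pyridin-3-yl or with the two five-membered rings, a result that would help separate ring size from the identity of the hetero atoms.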